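Trading the Benzoate Chain for a Propargyl Ether

The compounds below may be only part of what the source reports. "The series", "measured", "known", "first", "only" and "open" are said of these compounds alone.

compound 1 `O=C1c2ccccc2N(COCCO)S(=O)(=O)N1Cc1ccccc1`: 125 ug/mL
compound 2 `O=C(OCCOCN1c2ccccc2C(=O)N(Cc2ccccc2)S1(=O)=O)c1ccccc1`: 17 ug/mL

Among the measured compounds shown here, in a functional assay on HEL cells (Homo sapiens) (on this read-out higher numbers stand for lower toxicity in this test and lower numbers for higher toxicity in this test), compound 2 gives 17 ug/mL, the lower of the two numbers so far; compound 1 gives 125 ug/mL. Compound 3 `C#CCOCN1c2ccccc2C(=O)N(Cc2ccccc2)S1(=O)=O` differs from compound 2 by ethynyl in place of (benzoyloxy)methyl on a saturated chain carbon bound to an oxygen on a saturated carbon. For the measured compounds named here, the one measured step that bears on this is a 7.4-fold lower number from compound 1 to compound 2 (0.87 log units; beyond the scatter), in which the benzoyl group came in; in going to compound 3 that group leaves again, together with part of the chain, so a step back upward is expected, though the ethynyl end is new. Compound 3 is expected to give 70 ug/mL (range 25 ug/mL to 200 ug/mL), a step of a 4.1-fold higher number from compound 2 to compound 3 (0.61 log units; beyond the scatter).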

Compound 3, half-maximal cytotoxic concentration: > 50 ug/mL
Compound 3: no number, only a limit; the forecaster's own chance of this, stated with the estimate: 10%; the middle value lies beyond the limit too.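

Changing 2-(benzoyloxy)ethyl to propargyl at this position gives an at least 2.9-fold higher number from compound 2 to compound 3 (0.46 log units; beyond the scatter) in this assay and shows that the higher toxicity of the benzoate does not carry over to this shorter chain without a benzoyl group. Compound 3 gives > 50 ug/mL as a limit of the assay and not as a number. The step from compound 1 cannot be read, so the propargyl and hydroxyl-ended chains cannot be ranked. As far as these compounds go, whether an acetyl group in place of benzoyl, or an amine at the chain end, would also lower the number remains open.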